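The compounds below may be only part of what the source reports. "The series", "measured", "known", "first", "only" and "open" are said of these compounds alone.

Measured compounds in an ADME assay on HL-60 cells (Homo sapiens) for cytotoxicity, read by MTT assay, with a stated time of 3 days; a higher number here means that more compound is tolerated, a lower number that less compound is tolerated:
- compound 1, `Cc1cn([C@@H]2CC[C@H](CO)O2)c(=O)nc1N`: 950000 nM
- compound 2, `[N-]=[N+]=N[C@@H]1C[C@@H](n2ccc(NO)nc2=O)O[C@H]1CO`: 2000000 nM
- compound 3, `O=c1nc(NO)ccn1[C@@H]1CC[C@H](CO)O1`: 1600000 nM

Compound 1 gives the lowest of the three numbers in this assay. Its nearest neighbour is compound 3, whose value lies a step within the scatter away, so the two cannot be ordered; compound 2 sits a step beyond the scatter higher, so compound 2 is tolerated somewhat better than compound 1.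

The unmeasured compound 4, `Cc1cn([C@@H]2C[C@@H](F)[C@H](CO)O2)c(=O)nc1N`, differs from compound 1 by fluoro in place of hydrogen on a saturated ring carbon.

Within the data shown here, only one measured step touches a substituent on the saturated ring: from compound 2 to compound 3, a 1.3-fold lower number from compound 2 to compound 3 (0.10 log units; within the scatter). That step swaps azido for hydrogen on a saturated ring carbon and stays within the scatter, which suggests that a small change at a ring carbon of the saturated ring need not move the number. The step from hydrogen to fluoro is a different exchange at a different ring position, so this is only a loose guide, but it is the sole bearing on the question.

Compound 4 is therefore expected to give 1000000 nM, with a range of 500000 nM to 2000000 nM, the expected step of a 1.1-fold higher number from compound 1 to compound 4 (0.02 log units; within the scatter) not going beyond the scatter.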

Compound 4, half-maximal cytotoxic concentration: 1650000 nM
Estimate against measurement, compound 4: 1.7-fold (0.22 log units) below, and the stated range covers the measured number.
By their numbers in this assay, from the lowest: compounds 1, 3, 4 and 2 (each within the scatter of the next, the first and the last beyond it).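

In this assay, fluoro in place of hydrogen on the saturated ring carbon next to the ring atom that bears a hydroxymethyl group gives a 1.7-fold higher number from compound 1 to compound 4 (0.24 log units; within the scatter), so this exchange leaves the number within the scatter on this core. Among these compounds, until now, the only reading of a change on the saturated ring came from the exchange of azido for hydrogen, a 1.3-fold lower number from compound 2 to compound 3 (0.10 log units; within the scatter), on a different core; there are now two single-place changes on this ring, and both stay within the scatter, although two steps are too few to establish a pattern. No measured property is available to explain the size of the new step.

On these data alone, it remains open whether a hydroxyl, an amine or a chloro group at this ring carbon would also stay within the scatter on the core of compound 1. As far as these compounds go, it is equally open whether fluoro at this place would give a similar step on the core of compound 3.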